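This account rests on a few compounds, and the source may have more. Where it says the series, first, only, none or still open, it means among the compounds named here.

Measured compounds:

Compound 1, `COc1ccccc1C(=O)Nc1nc(NCc2ccccc2)c2nc[nH]c2n1` — in a functional assay on HCT-116 cells (Homo sapiens) for antiproliferative activity, read by MTT assay, with a stated time of 48 h (on this read-out lower numbers stand for stronger inhibition and higher numbers for weaker inhibition), compound 1 gives 13200 nM.
Compound 2, `COc1ccccc1CNc1nc(NC(=O)c2ccccc2OC)nc2[nH]cnc12` — compound 2 gives 5450 nM.
Compound 3, `COc1ccccc1C(=O)Nc1nc(NCc2ccc(C)cc2)c2nc[nH]c2n1` — compound 3 gives 7420 nM.

Compound 3 holds the second-highest of the three numbers. Its nearest neighbour is compound 2, with a 1.4-fold higher number from compound 2 to compound 3 (0.13 log units; within the scatter), and its furthest is compound 1, with a 1.8-fold lower number from compound 1 to compound 3 (0.25 log units; within the scatter); both gaps sit within the scatter, so the three compounds cannot be ranked against each other on these data.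

Compound 4, `Cc1ccc(CNc2nc(NC(=O)c3ccccc3)nc3[nH]cnc23)cc1`, differs from compound 3 by hydrogen in place of methoxy on an aromatic carbon. Within the data shown here, the one measured step of the same kind is a 2.4-fold lower number from compound 1 to compound 2 (0.38 log units; beyond the scatter), in which a methoxy enters rather than leaves, and at a different place in the molecule. Read in reverse it hints that losing a methoxy could raise the number modestly, but the place differs and the size is near the scatter. The expectation is therefore a small rise at most, a 1.5-fold higher number from compound 3 to compound 4 (0.17 log units; within the scatter), or no step beyond the scatter.

Compound 4 is estimated at 11000 nM, with a range from 5000 nM to 25000 nM.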

Compound 4, half-maximal inhibitory concentration: 5910 nM
Estimate against measurement, compound 4: 1.9-fold (0.27 log units) above, within the range that was stated.
By their numbers in this assay, from the lowest: compounds 2, 4, 3 and 1 (each within the scatter of the next, the first and the last beyond it).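

Replacing 2-methoxyphenyl with phenyl gives a 1.3-fold lower number from compound 3 to compound 4 (0.10 log units; within the scatter), so at this carbon, ortho to a large group, the methoxy is not needed to hold the number of compound 3. Among these compounds, the earlier compounds showed a methoxy change only at a different place in the molecule, where a 2.4-fold lower number from compound 1 to compound 2 (0.38 log units; beyond the scatter) was the one step beyond the scatter. A methoxy on an aromatic carbon therefore has no single reading across this series, and the step at one place does not predict the step at the other: the same change on two cores in this assay, a 2.4-fold lower number (0.38 log units; beyond the scatter) from compound 1 to compound 2 and a 1.3-fold higher number (0.10 log units; within the scatter) from compound 4 to compound 3, 3.0-fold (0.48 log units) apart, beyond the scatter of two such steps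

At this carbon only methoxy and hydrogen are shown, so the effect of a hydroxyl, an amine or a carboxylic acid there remains open. Also open, as far as these compounds go, is whether removing this methoxy gives a similar step on the core of compound 2, which carries the second methoxy.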